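Dimethylamino for carbamoyl on the chain of compound 3

A few compounds are considered here, and "the series" means these few. Any claim that something is new, unique, unknown or untested is made for them only; others in the source may bear on it.

Measured compounds:
compound 1, `C=CCn1c(=O)c2[nH]cnc2n(CCC)c1=O`, 1700 nM
compound 2, `C=CCCn1c(=O)c2[nH]cnc2n(CCC)c1=O`, 60 nM
compound 3, `CCCn1c(=O)n(CCC(N)=O)c(=O)c2[nH]cnc21`, 31500 nM

In an assay on Cerebral cortex for binding affinity to adenosine receptor A1 (Cavia porcellus), read by radioligand binding (on this read-out higher numbers stand for weaker inhibition and lower numbers for stronger inhibition), compound 3 gives the highest of the three numbers; compound 1 sits nearest and compound 2 furthest, as a 19-fold higher number from compound 1 to compound 3 (1.27 log units; beyond the scatter) and a 530-fold higher number from compound 2 to compound 3 (2.72 log units; beyond the scatter) show. Compound 4, `CCCn1c(=O)n(CCN(C)C)c(=O)c2[nH]cnc21`, differs from compound 3 by dimethylamino in place of carbamoyl on a saturated chain carbon, two bonds along the chain from an aromatic nitrogen. Among the compounds with values here, no measured step involves dimethylamino; the only steps at this place, a 530-fold higher number from compound 2 to compound 3 (2.72 log units; beyond the scatter) and a 28-fold lower number from compound 1 to compound 2 (1.45 log units; beyond the scatter), concern carbamoyl and allyl. Since the change removes the carbamoyl that accompanied the weakest number, a step downward in this assay is expected, but smaller than those steps, so compound 4 is expected at 5000 nM, within 1000 nM to 25000 nM, a step of a 6.3-fold lower number from compound 3 to compound 4 (0.80 log units; beyond the scatter).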

Compound 4, inhibition constant: 4300 nM
Beside the measured number, compound 4's estimate is 1.2-fold (0.07 log units) above it, and the stated range covers the measured number.
By their numbers in this assay, from the lowest: compound 2; then compound 1; then compound 4; then compound 3.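

In this assay, the 2-(dimethylamino)ethyl chain of compound 4 recovers only part of what the 2-carbamoylethyl chain gave up (a 7.3-fold lower number from compound 3 to compound 4 (0.86 log units; beyond the scatter)), showing that the number at this position is not fixed by the carbamoyl group alone. Compound 4 still stays far from the chain of compound 2 (a 72-fold higher number from compound 2 to compound 4 (1.86 log units; beyond the scatter)) and lies modestly short of compound 1 (a 2.5-fold higher number from compound 1 to compound 4 (0.40 log units; beyond the scatter)). Nothing available explains these steps.

On these data alone, it remains open whether the dimethylamino group itself matters or only the absence of carbamoyl. A primary amine, a carboxylic acid or a longer chain ending in dimethylamino at this position could separate the two.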